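The compounds below may be only part of what the source reports. "The series", "measured", "known", "first", "only" and "open" are said of these compounds alone.

Measured so far:
compound 1 `O=c1nc2oc(C3CC3)c(C#CC3CC3)c2cn1Cc1cn(Cc2ccccc2)nn1` — 4810 nM
compound 2 `O=c1nc2oc(CCCCl)c(C#CCCCCCl)c2cn1Cc1cn(-c2ccc(F)cc2)nn1` — 39400 nM
compound 3 `CCCCCc1ccc(C#Cc2c(-c3ccc(CCCCC)cc3)oc3nc(=O)n(Cc4cn(Cc5ccccc5)nn4)cc23)cc1` — > 100000 nM

In a functional assay on A549 cells (Homo sapiens) for antiproliferative activity, read by MTT assay, with a stated time of 72 h (on this read-out higher numbers stand for weaker inhibition and lower numbers for stronger inhibition), compound 1 gives 4810 nM and compound 2 gives 39400 nM. Compound 3 returns only a limit, > 100000 nM, which is the limit of > 100000 nM in this assay, at which 1 of the 3 values shown sits, and not a number. Among the two numbers shown, compound 2 stands highest, and compound 1 gives the lower number, a gap beyond the usual scatter.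

Compound 4 `O=c1nc2oc(CCCCl)cc2cn1Cc1cn(-c2ccc(F)cc2)nn1` has not yet been measured in this assay. It differs from compound 2 in one place: hydrogen in place of 6-chlorohex-1-yn-1-yl on an aromatic carbon. Within the data shown here, no step between two measured compounds that differ in one place is available here, so the size of this change must be guessed from the three compounds alone. Compound 1, with its small groups, gives the lowest number, while compound 3, with large groups on both sides, sits at the limit; on that slim basis the step from compound 2 to compound 4 is expected to be small, a 1.3-fold lower number from compound 2 to compound 4 (0.12 log units; within the scatter), and may well stay within the scatter. Compound 4 is therefore estimated at 30000 nM, with a range from 8000 nM to 100000 nM.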

Compound 4, half-maximal inhibitory concentration: 68400 nM
For compound 4 the middle estimate is 2.3-fold (0.36 log units) below the measured one; the measured number falls inside the stated range.
By their numbers in this assay, from the lowest: compound 1; then compounds 2 and 4 (each within the scatter of the next). At a limit, above all of these: compound 3.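

In this assay, the step at this position is small: a 1.7-fold higher number from compound 2 to compound 4 (0.24 log units; within the scatter). Here the 6-chlorohex-1-yn-1-yl group, with its 7 heavy atoms and triple bond, gives way to hydrogen on the aromatic carbon, and the two compounds cannot be told apart beyond the scatter, something the earlier compounds, which differ in more than one place, could not show. Nothing measured among the compounds shown accounts for this result.

Compounds 1 and 3 differ from compound 2 in more than one place, so they cannot show whether the group on this carbon matters when the rest of the molecule is different. On these data alone, it also remains open whether an amine, a carboxylic acid or a shorter alkynyl chain on this aromatic carbon, with the rest of compound 4 unchanged, would move the number beyond the scatter.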